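The source may hold more compounds than are shown below. What is called first, only, known or untested is meant among the compounds shown, and "the series" means these compounds.

Working notes on the series. Compound 3 `CCCCCCCCc1ccc(OC(C)C(=O)Cn2nnc(-c3ccccc3)n2)cc1` stands in an assay on microsomes from brain for inhibition of Fatty-acid amide hydrolase 1 (Rattus norvegicus), read by fluorescence and HPLC, with a stated time of 60 min (on this read-out lower numbers stand for stronger inhibition and higher numbers for weaker inhibition), at 24 nM, level with compound 1 `CCCCCCCCc1ccc(OCC(=O)Cn2nnc(-c3ccccc3)n2)cc1` at 24 nM; the two are together the lowest of the three numbers recorded so far. Compound 2 `CCCCCCCCc1ccc(OCC(=O)Cn2nnc(-c3ccc(C(=O)OC)cc3)n2)cc1` gives 29 nM in this assay. Across the measured pairs the movement is small: a 1.2-fold higher number from compound 1 to compound 2 (0.08 log units; within the scatter), and no change at the digits printed from compound 1 to compound 3 (within the scatter). Neither change has moved the number beyond the scatter.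

The next compound, compound 4 `CCCCCCCCc1ccc(OC(C)C(=O)Cn2nnc(-c3ccc(C(=O)OC)cc3)n2)cc1`, differs from compound 3 in one place: methoxycarbonyl in place of hydrogen on an aromatic carbon. The same change has already been seen once, from compound 1 to compound 2, where it read a 1.2-fold higher number from compound 1 to compound 2 (0.08 log units; within the scatter). The methyl on the chain carbon, which separates compound 3 from compound 1, made no difference at the digits recorded, so there is no reason in the numbers to expect the two changes to interact. The expectation for this assay is therefore a step of a 1.2-fold higher number from compound 3 to compound 4 (0.08 log units; within the scatter) that stays within the scatter, with no direction that can be called out.

On that basis compound 4 is estimated at 29 nM, with a range from 14 nM to 60 nM, and the measured value for compound 4 in this assay is awaited.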

Compound 4, half-maximal inhibitory concentration: 25 nM
For compound 4 the middle estimate is 1.2-fold (0.06 log units) above the measured one; measured number inside the range.
By their numbers in this assay, from the lowest: compounds 1, 3, 4 and 2 (each within the scatter of the next).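

Methoxycarbonyl on the aromatic carbon, para to a large group, has now been read on a second core, and in this assay the step is a 1.0-fold higher number from compound 3 to compound 4 (0.02 log units; within the scatter); phenyl to 4-(methoxycarbonyl)phenyl therefore leaves the number within the scatter on both cores: the same change on two cores in this assay, a 1.2-fold higher number (0.08 log units; within the scatter) from compound 1 to compound 2 and a 1.0-fold higher number (0.02 log units; within the scatter) from compound 3 to compound 4, 1.2-fold (0.06 log units) apart, within the scatter of two such steps. The methyl on the saturated chain carbon, earlier read only on the core of compound 1, has now been read with methoxycarbonyl present, giving a 1.2-fold lower number from compound 2 to compound 4 (0.06 log units; within the scatter), so this change also holds on both cores: the same change on two cores in this assay, no change at the digits printed (within the scatter) from compound 1 to compound 3 and a 1.2-fold lower number (0.06 log units; within the scatter) from compound 2 to compound 4, 1.2-fold (0.06 log units) apart, within the scatter of two such steps. Compound 4 carries both changes and still stays within the scatter of compound 3 and compound 2, so no interaction between the two places can be read from these four compounds, and none of them goes against this.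

On these data alone, what remains open is whether any group on this aromatic carbon can move the number beyond the scatter, for example a carboxylic acid or an amine in place of methoxycarbonyl. The same question stands for the chain carbon, where an ethyl group or a phenyl group in place of methyl would test how much this place accepts.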